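A few compounds are considered here, and "the series" means these few. Any claim that something is new, unique, unknown or untested is made for them only; others in the source may bear on it.

Two compounds in this set have a number in a functional assay on A549 cells (Homo sapiens) for cytotoxicity, read by sulforhodamine B assay, with a stated time of 72 h (on this read-out lower numbers stand for stronger inhibition and higher numbers for weaker inhibition), and compound 1, with the structure `CCS(=O)(=O)Nc1cc(-c2ccc3ncnc(Nc4ccc(OC)cc4)c3c2)cnc1OC`, stands lowest of the two: in this assay compound 1 gives 3580 nM. Among the measured compounds shown here, the only other measured compound is compound 2, with the structure `CCCCS(=O)(=O)Nc1cc(-c2ccc3ncnc(Nc4ccc(F)c(Cl)c4)c3c2)cnc1OC`, and in this assay compound 2 gives 77100 nM, a markedly higher number than that of compound 1; since the two differ in more than one place, their two values show only that compound 1 is the stronger of the pair and nothing about which change carries the difference.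

Compound 3, with the structure `CCS(=O)(=O)Nc1cc(-c2ccc3ncnc(Nc4ccc(F)nc4)c3c2)cnc1OC`, has not yet been measured in this assay. It differs from compound 1 in one place: 6-fluoropyridin-3-yl in place of 4-methoxyphenyl on a nitrogen on an aromatic ring. For the measured compounds named here, no measured pair in the set isolates a change of this kind, so the expectation rests on compound 1 alone. The expected step is estimated as a 2.2-fold higher number from compound 1 to compound 3 (0.35 log units; beyond the scatter), a modest loss. That expected loss is far smaller than the gap between compound 1 and compound 2. Compound 3 is accordingly estimated at 8000 nM in this assay, within a range from 2500 nM to 30000 nM.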

Compound 3, half-maximal inhibitory concentration: 6720 nM
The estimate for compound 3 lay 1.2-fold (0.08 log units) above the measured number; the measured number falls inside the stated range.
By their numbers in this assay, from the lowest: compounds 1 and 3 (each within the scatter of the next); then compound 2.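

In this assay, among the compounds shown here, the exchange of 4-methoxyphenyl for 6-fluoropyridin-3-yl on a nitrogen on an aromatic ring gives the first step in the set that isolates a single change: a 1.9-fold higher number from compound 1 to compound 3 (0.27 log units; within the scatter). This position can therefore hold a six-membered aromatic ring with a hetero atom and a fluorine, instead of a carbon-only ring with a methoxy group, without a change in the number that stands beyond the scatter, a reading that rests on this one pair. Nothing given here accounts for the two groups giving values within the scatter of each other in this assay.

The compounds shown leave open how the number would respond to an amine or a carboxylic acid on the group at this nitrogen, or to a saturated ring such as piperidine in place of the aromatic one. For the compounds shown here, they also leave the sulfonyl chain unresolved: compound 2 carries a butyl chain but also differs from compound 1 in its group on the nitrogen, so no single-change pair shows what a longer chain does on its own.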